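Replacing the 3-nitrophenyl group with 2,5-dichlorophenyl

This account rests on a few compounds, and the source may have more. Where it says the series, first, only, none or still open, it means among the compounds named here.

Among the compounds with values here, in a functional assay on HCT-116 cells (Homo sapiens) for inhibition, read by MTT assay, with a stated time of 2 days (a lower number here means a stronger inhibitor of growth, a higher number a weaker inhibitor of growth), compound 2 (`Nc1ccccc1NC(=O)CCCNCC(=O)Nc1cccc([N+](=O)[O-])c1`) gives 900 nM and holds the lower of the two numbers measured so far, while compound 1 (`Nc1ccccc1NC(=O)CCCNCC(=O)Nc1cccc(Cl)c1`) gives 11600 nM as the higher. Compound 3 (`Nc1ccccc1NC(=O)CCCNCC(=O)Nc1cc(Cl)ccc1Cl`) has not yet been measured and differs from compound 2 as follows (2,5-dichlorophenyl in place of 3-nitrophenyl on an amide-type nitrogen): 2,5-dichlorophenyl in place of 3-nitrophenyl on an amide-type nitrogen. Within the data shown here, only one measured step bears on this change (a 13-fold lower number from compound 1 to compound 2 (1.11 log units; beyond the scatter)), a large one with nitro in place of chloro on an aromatic carbon. Among the measured compounds shown here, compound 3 loses the nitro group and carries chlorine again, so much of that step is expected to reverse, though no measured compound carries the 2,5-dichlorophenyl group. The expected step is large and upward (a 6.7-fold higher number from compound 2 to compound 3 (0.82 log units; beyond the scatter)), beyond the scatter. In this assay compound 3 is expected at 6000 nM within an estimated range from 1800 nM to 18000 nM on repeated measurement.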

Compound 3, concentration for 50% growth inhibition: 31000 nM
For compound 3 the middle estimate is 5.2-fold (0.71 log units) below the measured one; the whole stated range lies below it.
By their numbers in this assay, from the lowest: compound 2; then compound 1; then compound 3.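

In this assay the 2,5-dichlorophenyl group on the amide-type nitrogen does far worse than the 3-nitrophenyl group (with a 34-fold higher number from compound 2 to compound 3 (1.54 log units; beyond the scatter)). The earlier compounds shown here showed only that chloro gives a higher number than nitro; this result shows that a further chlorine does not close that gap but widens it (with a 2.7-fold higher number from compound 1 to compound 3 (0.43 log units; beyond the scatter)). Among these three compounds, then, the chlorinated rings both stay well above compound 2, and adding chloro to the ring moves the number up rather than down.

From the compounds shown here alone, it stays open whether the low number belongs to the nitro group itself, which a nitrile, a methyl ester or an unsubstituted phenyl group on the same nitrogen would help to decide. The data shown offer no measured explanation for this order.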